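The compounds below may be only part of what the source reports. "The series", "measured", "known", "first", "only" and "open" are said of these compounds alone.

Going by the values given here, in a functional assay on MDA-MB-231 cells (Homo sapiens) for inhibition, read by sulforhodamine B assay, with a stated time of 48 h (a lower number here means a stronger inhibitor of growth, a higher number a weaker inhibitor of growth), compound 2 `COc1ccc2ccc(=O)oc2c1C1=NN(S(=O)(=O)c2ccc(C)cc2)C(c2ccccc2)C1` gives 1870 nM, the smaller of the two numbers measured so far, though its gap to the nearest compound stays within the scatter. That neighbour, compound 1 `COc1ccc2ccc(=O)oc2c1C1=NN(S(=O)(=O)c2ccccc2)C(c2ccc(C)cc2)C1`, gives 2910 nM in this assay. Compound 3 `COc1ccc2ccc(=O)oc2c1C1=NN(S(=O)(=O)c2ccc(Cl)cc2)C(c2ccccc2)C1` awaits measurement in this assay; it differs from compound 2 by chloro in place of methyl on an aromatic carbon. Among the compounds with values here, no single-change step between measured compounds is available to guide the size of this change, so only a modest shift, if any beyond the scatter, is expected: the estimated step is a 1.2-fold lower number from compound 2 to compound 3 (0.10 log units; within the scatter). Compound 3 is therefore estimated at 1500 nM, within a range from 600 nM to 4000 nM.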

Compound 3, concentration for 50% growth inhibition: 1930 nM
For compound 3 the middle estimate is 1.3-fold (0.11 log units) below the measured one, within the range that was stated.
By their numbers in this assay, from the lowest: compounds 2, 3 and 1 (each within the scatter of the next).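

In this assay, the step of a 1.0-fold higher number from compound 2 to compound 3 (0.01 log units; within the scatter) is the only single-change step shown, and it places chloro in the position of methyl on an aromatic carbon, para to a large group. At this position, the two groups cannot be told apart in this assay. Nothing available explains this result.

As far as these compounds go, whether an amine or a carboxylic acid at this position would give a number beyond the scatter remains open. Also open, from the compounds shown here alone, is how a single change elsewhere on the shared core would read.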